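The compounds below may be only part of what the source reports. "The series", "measured", "known", "first", "only" and "open" are said of these compounds alone.

Of the compounds shown here, three share one core and have been tested in an ADME assay on PBMC cells (Homo sapiens) for cytotoxicity, read by CellTiter-Glo, with a stated time of 72 h; a higher number here means a weaker inhibitor, a lower number a stronger inhibitor. Compound 1 `CO[C@@H]1[C@H](N(C)c2ncc(-c3c[nH]c4ccc(Cl)cc34)s2)C[C@H]2O[C@]1(C)n1c3ccccc3c3c4c(c5c6ccccc6n2c5c31)C(=O)NC4` carries a chloro group on its indole part. In this assay compound 1 gives > 10000 nM, which is a limit of the assay and not a number. Compound 2 `CO[C@@H]1[C@H](N(C)c2ncc(-c3c[nH]c4ccccc34)s2)C[C@H]2O[C@]1(C)n1c3ccccc3c3c4c(c5c6cc(Cl)ccc6n2c5c31)C(=O)NC4` instead carries a chloro group on the shared core. In this assay compound 2 stops at > 10000 nM, again a limit. Compound 3 `CO[C@@H]1[C@H](N(C)c2ncc(-c3c[nH]c4ccccc34)s2)C[C@H]2O[C@]1(C)n1c3ccccc3c3c4c(c5c6cc(Br)ccc6n2c5c31)C(=O)NC4` has bromo in place of that chloro. In this assay compound 3 gives > 10000 nM, once more a limit. The step that the two limits leave unreadable from compound 2 to compound 3 therefore cannot be read in size. Within the data shown here, all three values sit at the same limit (the limit of > 10000 nM in this assay, at which 3 of the 3 values shown sit), so no step among them can be resolved.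

Compound 4 `CO[C@@H]1[C@H](N(C)c2ncc(-c3c[nH]c4ccc(Cl)cc34)s2)C[C@H]2O[C@]1(C)n1c3ccccc3c3c4c(c5c6cc(Br)ccc6n2c5c31)C(=O)NC4` combines the two halogens: compared with compound 3, the change is chloro in place of hydrogen on an aromatic carbon. Among the measured compounds shown here, no measured step in this assay bears directly on this change, and the one measured step was unreadable. Compound 1 already carries this chloro group on the indole and sits at > 10000 nM, a limit. Compound 3 sits at > 10000 nM, also a limit. Nothing therefore points toward a readable shift. The step of a number no higher from compound 3 to compound 4 (the limit leaves the size open) is expected to be none beyond the scatter. For compound 4 in this assay the estimate is 10000 nM, within 5000 nM to 30000 nM, and most likely only the limit is reported again.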

Compound 4, half-maximal inhibitory concentration: > 10000 nM
Compound 4: no number, only a limit (the forecaster's own chance of this, stated with the estimate: 85%); the middle value lies on the limit itself.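

In this assay compound 4 gives > 10000 nM, which is a limit and not a number. The steps to compound 4 from compound 3 and from compound 1 therefore cannot be read in size, as every value stands at the same limit: the limit of > 10000 nM in this assay, at which 4 of the 4 values shown sit. The compounds shown leave open how far each true value lies past that limit, and so whether compounds 1, 2, 3 and 4 differ at all.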